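The compounds below may be only part of what the source reports. "The series", "measured", "known", "first", "only" and "open" are said of these compounds alone.

Of the compounds shown here, three built on one shared core have been measured in a functional assay on U2OS cells (Homo sapiens) for antiproliferative activity, read by MTT assay, with a stated time of 72 h; on this read-out lower numbers stand for stronger inhibition and higher numbers for weaker inhibition. Compound 1 `O=C(C1=C(OC2CCCCC2)C(=O)N(CCCn2ccnc2)C1c1ccc(Br)cc1)c1ccccc1` gives 22400 nM. Compound 2 `O=C(C1=C(Nc2ccc(Br)cc2)C(=O)N(CCCn2ccnc2)C1c1ccc(Br)cc1)c1ccccc1` gives 13000 nM, and compound 3 `O=C(C1=C(Nc2ccccc2Br)C(=O)N(CCCn2ccnc2)C1c1ccc(Br)cc1)c1ccccc1` gives 16900 nM. Among these three numbers compound 3 stands second highest; its nearest neighbour is compound 2, with a 1.3-fold higher number from compound 2 to compound 3 (0.11 log units; within the scatter), and its furthest is compound 1, with a 1.3-fold lower number from compound 1 to compound 3 (0.12 log units; within the scatter), so all three lie within the scatter of one another.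

Compound 4 `O=C(C1=C(NCc2ccccc2)C(=O)N(CCCn2ccnc2)C1c1ccc(Br)cc1)c1ccccc1` differs from compound 3 by benzyl in place of 2-bromophenyl on an amine nitrogen. Two kinds of measured step bear on this change. Exchanging one bromophenyl for another on the amine nitrogen produced a step within the scatter, as noted above. Replacing cyclohexyloxy with (4-bromophenyl)amino or (2-bromophenyl)amino produced a 1.7-fold lower number from compound 1 to compound 2 (0.24 log units; within the scatter) and a 1.3-fold lower number from compound 1 to compound 3 (0.12 log units; within the scatter), again within the scatter. Going by the values given here, no measured step on this nitrogen has moved the number beyond the scatter, so no change beyond the scatter is expected in this assay for compound 4. Compound 4 is therefore estimated at 16000 nM, with a range from 6000 nM to 45000 nM. That estimate corresponds to an expected 1.1-fold lower number from compound 3 to compound 4 (0.02 log units; within the scatter).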

Compound 4, half-maximal inhibitory concentration: 32500 nM
Compound 4: middle estimate off by 2.0-fold (0.31 log units), on the low side; the range from low to high includes it.
By their numbers in this assay, from the lowest: compounds 2, 3, 1 and 4 (each within the scatter of the next, the first and the last beyond it).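

Benzyl gives the first step on this amine nitrogen that passes the scatter in this assay: in place of 4-bromophenyl it gives a 2.5-fold higher number from compound 2 to compound 4 (0.40 log units; beyond the scatter), whereas in place of 2-bromophenyl it gives a 1.9-fold higher number from compound 3 to compound 4 (0.28 log units; within the scatter), and benzylamino in place of cyclohexyloxy gives a 1.5-fold higher number from compound 1 to compound 4 (0.16 log units; within the scatter). Only the first of these steps separates two compounds, and it is modest, so swapping the aromatic group directly on the nitrogen for benzyl can raise the number, but the size of that rise depends on which compound it is read against. Nothing measured here accounts for this difference.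

The compounds shown leave open whether 4-bromobenzyl or phenethyl on this nitrogen would give a number closer to compound 2 or to compound 4. They also leave open how an unsubstituted phenyl or a cyclohexyl on the same nitrogen would compare.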